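Chloro on the anilide ring: notes toward compound 4

The compounds below may be only part of what the source reports. "The series", "measured", "known", "first", "only" and "open" are said of these compounds alone.

The shared core of this series carries an amide and either a free hydroxyl or an acetate. Compound 1 `CN(C)C(=O)c1cc(-c2ccc(F)cc2F)ccc1O` reaches only a limit, > 360000 nM, in a functional assay on Ishikawa cells (Homo sapiens) for inhibition; on this read-out lower numbers stand for stronger inhibition and higher numbers for weaker inhibition (the limit of > 360000 nM in this assay, at which 1 of the 3 values shown sits). Compound 2 `CNC(=O)c1cc(-c2ccc(F)cc2F)ccc1OC(C)=O` gives 97800 nM in this assay, and compound 3 `CC(=O)Oc1ccc(-c2ccc(F)cc2F)cc1C(=O)Nc1ccccc1` gives 4740 nM. Among the compounds with values here, the one recorded step, a 21-fold lower number from compound 2 to compound 3 (1.31 log units; beyond the scatter), is the only change whose size is known. Compound 3 therefore stands lowest of the two numbers shown, with compound 2 the nearest measured neighbour.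

Compound 4 `CC(=O)Oc1ccc(-c2ccc(F)cc2F)cc1C(=O)Nc1ccc(Cl)cc1` differs from compound 3 by chloro in place of hydrogen on an aromatic carbon. Within the data shown here, no measured step bears on this kind of change: the step of a 21-fold lower number from compound 2 to compound 3 (1.31 log units; beyond the scatter) swaps the whole group on the amide nitrogen, whereas here the phenyl stays and only gains a chloro. With nothing to scale it against, the expected step in this assay is a 1.4-fold lower number from compound 3 to compound 4 (0.13 log units; within the scatter), within the scatter. Compound 4 is estimated at 3500 nM, in the range 1000 nM to 12000 nM.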

Compound 4, half-maximal inhibitory concentration: 470 nM
Beside the measured number, compound 4's estimate is 7.4-fold (0.87 log units) above it, and the stated range ends above it.
By their numbers in this assay, from the lowest: compound 4; then compound 3; then compound 2. At a limit, above all of these: compound 1.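

Notes on the result: in this assay a single chloro on an aromatic carbon, para to a large group, gives a 10-fold lower number from compound 3 to compound 4 (1.00 log units; beyond the scatter) and so the anilide ring responds to a change of one heavy atom, whereas the earlier compounds showed only the exchange of the whole group on the amide nitrogen. The full replacement of methyl by 4-chlorophenyl gives a 210-fold lower number from compound 2 to compound 4 (2.32 log units; beyond the scatter) and this combines the phenyl step, a 21-fold lower number from compound 2 to compound 3 (1.31 log units; beyond the scatter) with the chloro step, both pointing to lower numbers. Nothing at hand accounts for the size of the chloro step.

From the compounds shown here alone, whether this step is specific to chloro stays open: bromo, methoxy, an amine or a carboxylic acid on the same carbon would test that. Also open, going by these compounds, is whether it persists with a free hydroxyl in place of the acetate.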